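Extending the hexyloxy chain of compound 3

The compounds below may be only part of what the source reports. "The series", "measured", "known", "first", "only" and "open" are said of these compounds alone.

In a functional assay on brain (Rattus norvegicus, strain Wistar) for inhibition (a lower number here means a stronger inhibitor, a higher number a weaker inhibitor), compound 1 (`CCCCCCOc1ccc(-c2c(C)[nH]c(=O)n2C)cc1`) gives 7300 nM and compound 2 (`CCCCCc1ccc(-c2c(C)[nH]c(=O)n2C2CCCCC2)cc1`) gives 10600 nM while compound 3 (`CCCCCCOc1ccc(-c2c(C)[nH]c(=O)n2C2CCCCC2)cc1`) gives 8500 nM and so lies within the scatter of both. Compound 4 (`CCCCCCCCCCCCOc1ccc(-c2c(C)[nH]c(=O)n2C2CCCCC2)cc1`) differs from compound 3 by hexyl in place of hydrogen on a saturated chain carbon, six bonds along the chain from an oxygen on an aromatic ring in the chain. For the measured compounds named here, two measured steps bear on this only loosely: cyclohexyl in place of methyl on an aromatic nitrogen gives a 1.2-fold higher number from compound 1 to compound 3 (0.07 log units; within the scatter) and hexyloxy in place of pentyl on an aromatic carbon gives a 1.2-fold lower number from compound 2 to compound 3 (0.10 log units; within the scatter) with both inside the scatter. As far as these compounds go, neither tests a chain this long, so the direction stays open. The expected step of a 1.4-fold lower number from compound 3 to compound 4 (0.15 log units; within the scatter) is no change beyond the scatter, with wide bounds. Compound 4 is estimated at 6000 nM within a range from 1800 nM to 20000 nM in this assay.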

Compound 4, half-maximal inhibitory concentration: 52400 nM
The estimate for compound 4 lay 8.7-fold (0.94 log units) below the measured number; measured number above the stated range.
By their numbers in this assay, from the lowest: compounds 1, 3 and 2 (each within the scatter of the next); then compound 4.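

Hexyl in place of hydrogen on a saturated chain carbon, six bonds along the chain from an oxygen on an aromatic ring, gives a 6.2-fold higher number from compound 3 to compound 4 (0.79 log units; beyond the scatter) in this assay, so inhibition weakens. For the compounds shown here, this is the first step to lie beyond the scatter, so this position responds to chain extension, whereas the two earlier steps showed no change beyond the scatter. Nothing at hand explains the loss.

As far as these compounds go, whether the number rises gradually or abruptly with chain length stays open, as does the effect of a shorter extension such as propyl. Also open, from the compounds shown here alone, is whether an amine or a carboxylic acid at the end of the chain would behave like hexyl.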